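Pyridine-2-carboximidamide thiosemicarbazides: growth inhibition on A-375

This account rests on a few compounds, and the source may have more. Where it says the series, first, only, none or still open, it means among the compounds named here.

Measured so far:
compound 1 `N/C(=N\NC(=S)N1CCSCC1)c1ccccn1` — 80%
compound 2 `N/C(=N\NC(=S)N1CCCCCC1)c1ccccn1` — 78.6%
compound 3 `Cc1ccnc(/C(N)=N/NC(=S)N2CCN(c3ccccn3)CC2)c1` — 74.8%

All three values come from a functional assay on A-375 cells (Homo sapiens) for cytotoxicity, read by MTT assay, with a stated time of 72 h, tested at 3 uM; on this read-out higher numbers stand for more inhibition of growth at the one concentration tested and lower numbers for less inhibition of growth. Compound 3 gives 74.8%, the lowest of the three numbers, but its gap to compound 2 and its gap to compound 1 both lie within the scatter, so no order among the three can be read from the data.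

The next compound in the series is compound 4 `N/C(=N\NC(=S)N1CCN(c2ccccn2)CC1)c1ccccn1`. It differs from compound 3 in one place: hydrogen in place of methyl on an aromatic carbon. Cut one bond further out, the change reads 4-methylpyridin-2-yl to pyridin-2-yl; the remainder of the molecule, including the thiosemicarbazide link and the piperazine bearing a pyridin-2-yl group, is unchanged.

For the measured compounds named here, no pair of measured compounds isolates this change, so its effect in this assay is unknown. Given that the three measured compounds sit together within the scatter despite differing widely in the amine part, the step from compound 3 to compound 4 is expected to be small, a number 1.2 percentage points higher from compound 3 to compound 4 (within the scatter), with no direction resolved beyond the scatter. Compound 4 is therefore estimated at 76%, expected to fall between 63% and 88%.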

Compound 4, percent growth inhibition at one concentration: 73.7%
The estimate for compound 4 lay 2.3 percentage points above the measured number, and the stated range covers the measured number.
By their numbers in this assay, from the lowest: compounds 4, 3, 2 and 1 (each within the scatter of the next).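

For the compounds shown here, compound 3 and compound 4 form the first pair that differs in one place, and in this assay hydrogen in place of methyl gives a number 1.1 percentage points lower from compound 3 to compound 4 (within the scatter). At this position, on an aromatic carbon opposite the ring nitrogen, the methyl group can therefore be removed without a change that can be told from the scatter, at least while the piperazine bearing a pyridin-2-yl group stays in place. No measurement here bears on the reason for this result.

Going by these compounds, it remains open whether a different group at the same carbon, such as chlorine, methoxy, an amine, a carboxylic acid or a longer chain such as propyl, would shift the number beyond the scatter. Also open, on these data alone, is whether methyl and hydrogen would be equally hard to tell apart in compounds carrying the amine parts of compound 1 and compound 2.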